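A few compounds are considered here, and "the series" means these few. Any claim that something is new, unique, unknown or untested is made for them only; others in the source may bear on it.

Compound 1 `COC[C@H]1CCCN(c2ccnc3sc(C(N)=O)c(N)c23)C1`: 251 nM
Compound 2 `CCOCCOC[C@H]1CCCN(c2cc(C)nc3sc(C(N)=O)c(N)c23)C1`: 909 nM

In an ADME assay on the whole organism (Rattus norvegicus, strain Fischer 344) for pharmacokinetics, at a dose of 3 mg/kg by the oral route (on this read-out lower numbers stand for lower exposure and higher numbers for higher exposure at the dose given), compound 2 gives 909 nM, the higher of the two numbers and clear of the scatter from compound 1. Compound 3 `CCOCCOC[C@H]1CCCN(c2ccnc3sc(C(N)=O)c(N)c23)C1` has hydrogen in place of methyl on an aromatic carbon. For the measured compounds named here, no measured step isolates this change, so the expectation is uncertain. Compound 1, which also lacks that methyl, gives 251 nM, and this points downward. A moderate fall is expected, a 1.8-fold lower number from compound 2 to compound 3 (0.26 log units; within the scatter). Compound 3 is estimated at 500 nM, with an expected range of 180 nM to 1300 nM.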

Compound 3, maximal plasma concentration in the Rattus norvegicus assay: 2120 nM
For compound 3 the middle estimate is 4.2-fold (0.63 log units) below the measured one; the measured number lies above the stated range.
By their numbers in the Rattus norvegicus assay, from the lowest: compound 1; then compound 2; then compound 3.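

In the Rattus norvegicus assay, compound 3 gives 2120 nM; hydrogen in place of methyl on the aromatic carbon next to the ring nitrogen gives a 2.3-fold higher number from compound 2 to compound 3 (0.37 log units; beyond the scatter); with that hydrogen in both compounds, ethoxymethyl in place of hydrogen on a saturated chain carbon bound to an oxygen on a saturated carbon gives an 8.4-fold higher number from compound 1 to compound 3 (0.93 log units; beyond the scatter). In a physicochemical assay for solubility, at pH 6.8 (a higher number here means a more soluble compound, a lower number a less soluble compound), compound 2 gives 560 ug/mL and compound 3 gives 500 ug/mL; the same methyl change gives a 1.1-fold lower number from compound 2 to compound 3 (0.05 log units; within the scatter), so the gain in exposure comes with no solubility difference beyond the scatter. Nothing measured here explains why exposure responds to either change. On these data alone, whether a methoxy or a chlorine on that aromatic carbon, or a longer chain in place of ethoxymethyl, would keep this exposure remains open.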